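Lengthening an alkyl chain on a shared core

This account rests on a few compounds, and the source may have more. Where it says the series, first, only, none or still open, it means among the compounds named here.

The measured compounds:
- Compound 1, `CCc1nnc(SCc2ccccc2)n1N1C(=O)c2ccccc2C1=O`, gives in a functional assay on PC-3M cells (Homo sapiens) for cytotoxicity, read by MTT assay, with a stated time of 48 h (a higher number here means a weaker inhibitor, a lower number a stronger inhibitor), a value that is only a limit of the assay, > 200000 nM.
- Compound 2, `CCc1nnc(SCC(=O)c2ccccc2)n1N1C(=O)c2ccccc2C1=O`, gives in this assay likewise only a limit, > 200000 nM.
- Compound 3, `CCc1nnc(SC)n1N1C(=O)c2ccccc2C1=O`, gives in this assay again only a limit, > 200000 nM.

Compound 2 therefore has no number of its own in this assay, and the two companions shown stand at the same limit, as the limit of > 200000 nM in this assay, at which 3 of the 3 values shown sit, records. The steps among them, a step that the two limits leave unreadable from compound 1 to compound 2, a step that the two limits leave unreadable from compound 1 to compound 3 and a step that the two limits leave unreadable from compound 2 to compound 3, cannot be sized, so they say nothing about how changes at the sulfur-bound chain move the read-out.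

Compound 4, `CCCc1nnc(SCC(=O)c2ccccc2)n1N1C(=O)c2ccccc2C1=O`, differs from compound 2 by methyl in place of hydrogen on a saturated chain carbon, two bonds along the chain from an aromatic carbon. Going by the values given here, no measured step concerns this position, and the only evidence is that three compounds sharing the core all sit at the limit. The expected step from compound 2 to compound 4 is a step that the limit leaves unreadable from compound 2 to compound 4, meaning no movement beyond the scatter. Compound 4 is expected to remain at or near the limit, around 300000 nM, within 100000 nM to 1000000 nM.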

Compound 4, half-maximal inhibitory concentration: > 200000 nM
Compound 4: a limit, no number; the forecaster's own chance of this, stated with the estimate: 85%; the middle value does not contradict the limit.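

Compound 4, like compound 2, gives only a limit and not a number, so no step between the two can be read, and all the compounds shown stop at the same point: the limit of > 200000 nM in this assay, at which 4 of the 4 values shown sit. The compounds shown leave open whether any change on the shared core would give a measurable number in this assay.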